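The source may hold more compounds than are shown below. What is called first, only, known or untested is meant among the compounds shown, and "the series" means these compounds.

Of the compounds shown here, three have been measured so far in a toxicity assay on HepG2 2.2.15 cells (Homo sapiens) for cytotoxicity, read by CCK-8 assay, with a stated time of 8 days; a higher number here means that more compound is tolerated, a lower number that less compound is tolerated. Compound 1 `CCOC(=O)c1cn(-c2nccs2)nc1CC(C)C` carries an ethoxy group on its carbonyl carbon; in this assay compound 1 reaches only > 100000 nM, which is a limit of the assay and not a number. Compound 2 `CC(C)Cc1nn(-c2nccs2)cc1C(=O)Nc1ccc(F)cc1` carries a (4-fluorophenyl)amino group on that carbonyl carbon instead, and in this assay compound 2 gives 83700 nM. Compound 3 `CC(C)Cc1nn(-c2cccc(F)c2)cc1C(=O)Nc1ccc(F)cc1` has a 3-fluorophenyl in place of the 1,3-thiazol-2-yl on an aromatic nitrogen, and in this assay compound 3 gives 36200 nM. Of the two plain numbers, compound 2 holds the higher one, with compound 3 nearest through a modest step of a 2.3-fold lower number from compound 2 to compound 3 (0.36 log units; beyond the scatter), while compound 1 contributes a limit (the limit of > 100000 nM in this assay, at which 1 of the 3 values shown sits).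

Compound 4 `CC(C)Cc1nn(-c2nccs2)cc1C(=O)NCc1ccc(N)cc1` is not yet measured. It keeps the 1,3-thiazol-2-yl of compound 2 and alters only the amide part: 4-aminobenzyl in place of 4-fluorophenyl on an amide-type nitrogen. Of the measured steps, only the change at the carbonyl carbon from compound 1 to compound 2 touches this region, and that step was an at least 1.1-fold lower number from compound 1 to compound 2 (0.07 log units; that floor lies within the scatter), at the floor of the scatter. The swap on the aromatic nitrogen from compound 2 to compound 3 concerns another part of the molecule. In this assay the step of a 1.0-fold lower number from compound 2 to compound 4 (0.02 log units; within the scatter) is therefore expected to be small, without a clear direction. Compound 4 is estimated at 80000 nM in this assay, within a range from 30000 nM to 150000 nM, and a reading that again stops at the limit would not surprise.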

Compound 4, half-maximal cytotoxic concentration: > 100000 nM
Compound 4: a limit, no number; the forecaster's own chance of this, stated with the estimate: 35%; middle value at least 1.2-fold (0.09 log units) away from the limit.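

In this assay compound 4 gives > 100000 nM, which is a limit of the assay and not a number. This is the first change shown on the amide-type nitrogen itself: 4-aminobenzyl, which keeps a six-membered aromatic ring of carbon only and has a hydrogen-bond donor and acceptor that 4-fluorophenyl lacks, gives an at least 1.1-fold higher number from compound 2 to compound 4 (0.07 log units; that floor lies within the scatter), so the change shows no sign of lowering the number, while the true size of the step stays unknown. The limit is also no longer confined to compound 1, the ethoxy compound, because a compound with an amide now sits there too: the limit of > 100000 nM in this assay, at which 2 of the 4 values shown sit.

The compounds shown change the benzyl link and the amino group together, so they leave open which of the two matters, and a plain benzyl or a 4-aminophenyl on that nitrogen would pull them apart. Also open, on these data alone, is whether a longer chain or a carboxylic acid on the ring of this group would give a readable number rather than another limit.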